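Chloro to methyl on the benzyl group: expected growth inhibition

A few compounds are considered here, and "the series" means these few. Any claim that something is new, unique, unknown or untested is made for them only; others in the source may bear on it.

In a functional assay on HL-60 cells (Homo sapiens) for inhibition, read by CCK-8 assay, with a stated time of 48 h, tested at 20 uM (on this read-out lower numbers stand for less inhibition of growth and higher numbers for more inhibition of growth at the one concentration tested), compound 1 `Cc1ccc(S(=O)(=O)Oc2ccccc2/C=C(\C#N)C(=O)Nc2nnc(C)s2)cc1` gives 78%, compound 2 `Cc1ccc(S(=O)(=O)Oc2ccccc2/C=C(\C#N)C(=O)Nc2nnc(Cc3cccc4ccccc34)s2)cc1` gives 19% and compound 3 `Cc1ccc(S(=O)(=O)Oc2ccccc2/C=C(\C#N)C(=O)Nc2nnc(Cc3ccc(Cl)cc3)s2)cc1` gives 15%. Compound 3 shares the low end of these numbers with compound 2, and the two are not separated: a number 4 percentage points lower from compound 2 to compound 3 (within the scatter). Both lie far from compound 1, with a number 59 percentage points lower from compound 1 to compound 2 (beyond the scatter) and a number 63 percentage points lower from compound 1 to compound 3 (beyond the scatter), each a large drop.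

Compound 4 `Cc1ccc(Cc2nnc(NC(=O)/C(C#N)=C/c3ccccc3OS(=O)(=O)c3ccc(C)cc3)s2)cc1` keeps everything but one group: methyl in place of chloro on an aromatic carbon. This is methyl in place of chloro on an aromatic carbon, para to a large group, so 4-chlorobenzyl becomes 4-methylbenzyl.

Among the measured compounds shown here, no measured step covers this exact swap. The closest evidence is the exchange of naphthalen-1-yl for 4-chlorophenyl, a number 4 percentage points lower from compound 2 to compound 3 (within the scatter), which stayed within the scatter, whereas the large steps came from adding an aryl group at all. Compound 4 retains such a group, so no step beyond the scatter is expected. The estimated step is a number 3 percentage points higher from compound 3 to compound 4 (within the scatter). Compound 4 is estimated at 18%, with an expected range of 6% to 35%.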

Compound 4, percent growth inhibition at one concentration: 17%
Beside the measured number, compound 4's estimate is 1 percentage points above it, and the stated range covers the measured number.
By their numbers in this assay, from the lowest: compounds 3, 4 and 2 (each within the scatter of the next); then compound 1.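

In this assay, methyl in place of chloro on an aromatic carbon, para to a large group, gives a number 2 percentage points higher from compound 3 to compound 4 (within the scatter) and so does not separate these two groups at this position. With a number 2 percentage points lower from compound 2 to compound 4 (within the scatter) as well as a number 61 percentage points lower from compound 1 to compound 4 (beyond the scatter) in the same read-out, the 4-methylbenzyl group joins 4-chlorobenzyl and naphthalen-1-ylmethyl at the low end, and no compound shown goes against this large drop from the methyl of compound 1. Nothing measured here bears on the cause of these steps.

From the compounds shown here alone, whether an amine or a carboxylic acid at this same position would leave the number where it stands remains open. Also open, going by these compounds, is how a longer chain without an aryl group, such as propyl in place of the methyl of compound 1, would compare with compound 1.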